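Amide ring swap on a serine protease inhibitor series

This account rests on a few compounds, and the source may have more. Where it says the series, first, only, none or still open, it means among the compounds named here.

Of the compounds shown here, two of one series have so far been measured in an assay on isolated protein for inhibition of serine protease 1 (Bos taurus); a higher number here means a weaker inhibitor, a lower number a stronger inhibitor. Among the measured compounds shown here, compound 1, `Cc1c(F)c(Oc2cccc(C(=N)N)c2)nc(Oc2cccc([N+](=O)[O-])c2)c1F`, is the first of them. In this assay compound 1 gives only a limit, > 5000 nM, and no number. Compound 2, `Cc1c(F)c(Oc2cccc(C(=N)N)c2)nc(Oc2cccc(C(=O)N3CCCC3)c2)c1F`, carries a (pyrrolidin-1-yl)carbonyl where compound 1 carries a nitro group; in this assay compound 2 gives 2800 nM. For the measured compounds named here, the single step between them reads an at least 1.7-fold lower number from compound 1 to compound 2 (0.25 log units; that floor lies within the scatter), and since one of the two values sits at a limit (the limit of > 5000 nM in this assay, at which 1 of the 2 values shown sits), its true size is not known. Going by the values given here, compound 2 therefore holds the only number in this assay, and it stands above the limit of compound 1.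

The third compound, compound 3, `Cc1c(F)c(Oc2cccc(C(=N)N)c2)nc(Oc2cccc(C(=O)N3CCOCC3)c2)c1F`, differs from compound 2 in one place: morpholin-4-yl in place of pyrrolidin-1-yl on a carbonyl carbon. Among the compounds with values here, no measured step in this assay covers this kind of change; the only step measured concerns the exchange of a nitro for an amide, not an exchange within the amide. Compound 3 is therefore expected to stay close to compound 2, with a step of a 1.3-fold higher number from compound 2 to compound 3 (0.10 log units; within the scatter) and no direction beyond the scatter. The estimated value for compound 3 is 3500 nM, within a range from 1400 nM to 9000 nM.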

Compound 3, inhibition constant: > 5000 nM
Compound 3 was reported as a limit; the forecaster's own chance of this, stated with the estimate: 25%; middle value at least 1.4-fold (0.15 log units) from the limit.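

Adding the ring oxygen and going from the five-membered to the six-membered ring on the carbonyl carbon does not keep a measurable number in this assay: the step reads an at least 1.7-fold higher number from compound 2 to compound 3 (0.25 log units; that floor lies within the scatter). This shows that a (pyrrolidin-1-yl)carbonyl and a (morpholin-4-yl)carbonyl cannot be treated as interchangeable on the evidence so far, although the floor of that step does not by itself establish a change beyond the scatter, and that an amide at this place does not by itself give a number, since compound 2 alone has one. The step from compound 1 to compound 3 cannot be read, and the true size of the step to compound 3 stays unknown, because the values concerned sit at a limit: the limit of > 5000 nM in this assay, at which 2 of the 3 values shown sit.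

The compounds shown leave open how far past the limit compound 3 lies, and so whether the change from pyrrolidin-1-yl to morpholin-4-yl exceeds the scatter at all. They also leave open whether piperidin-1-yl, which has the six-membered ring without the oxygen, or a diethylamino group on the same carbonyl carbon would give a number in this assay, which would help separate ring size from the ring oxygen.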